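The source may report more compounds than this note shows. Statements on the series, on what has been measured and on what is new or still open speak of the compounds shown alone.

Series notes, aryl variation on the shared core. Among the measured compounds shown here, compound 1 `O=C(/C=C/c1ccc2c(c1)B(O)OC2)c1ccc(F)cc1` gives 2800 nM in a functional assay on HCT-116 cells (Homo sapiens) for cytotoxicity, read by MTT assay, with a stated time of 48 h (a higher number here means a weaker inhibitor, a lower number a stronger inhibitor), the lowest of the three numbers measured so far. Compound 2 `O=C(/C=C/c1ccc2c(c1)B(O)OC2)c1ccc(C(F)(F)F)cc1` gives 6300 nM in this assay, and compound 3 `CCOC(=O)c1ccc(C(=O)/C=C/c2ccc3c(c2)B(O)OC3)cc1` gives 7600 nM. Both measured departures from compound 1 raise the number: a 2.3-fold higher number from compound 1 to compound 2 (0.35 log units; beyond the scatter) and a 2.7-fold higher number from compound 1 to compound 3 (0.43 log units; beyond the scatter). Compounds 2 and 3 sit within the scatter of each other, a 1.2-fold higher number from compound 2 to compound 3 (0.08 log units; within the scatter).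

Compound 4 `Nc1cccc(C(=O)/C=C/c2ccc3c(c2)B(O)OC3)c1` is not yet measured in this assay. Relative to compound 1 the change is 3-aminophenyl in place of 4-fluorophenyl on a carbonyl carbon. For the measured compounds named here, no measured step exchanges the whole aryl group in this way; the two steps that start from compound 1 each put another group in place of fluoro on an aromatic carbon, and each cost a modest amount, with no measured step in the set showing a gain. A modest weakening is therefore the more likely outcome for compound 4, though a step within the scatter cannot be excluded, because the guiding steps were only a 2.3-fold higher number from compound 1 to compound 2 (0.35 log units; beyond the scatter) and a 2.7-fold higher number from compound 1 to compound 3 (0.43 log units; beyond the scatter). For compound 4 a step of a 1.6-fold higher number from compound 1 to compound 4 (0.21 log units; within the scatter) is expected. The estimate for compound 4 is 4500 nM, with a range from 1800 nM to 11000 nM.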

Compound 4, half-maximal inhibitory concentration: 4500 nM
Compound 4: the middle estimate sits on the measured number at the digits printed, within the range that was stated.
By their numbers in this assay, from the lowest: compounds 1, 4, 2 and 3 (each within the scatter of the next, the first and the last beyond it).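

In this assay the exchange on the carbonyl carbon gives a 1.6-fold higher number from compound 1 to compound 4 (0.21 log units; within the scatter), so the data do not separate 3-aminophenyl, with its hydrogen-bond donor and acceptor, from 4-fluorophenyl, which has neither. Among the compounds shown here, this is the first departure from compound 1 that stays within the scatter, whereas the earlier ones were a 2.3-fold higher number from compound 1 to compound 2 (0.35 log units; beyond the scatter) and a 2.7-fold higher number from compound 1 to compound 3 (0.43 log units; beyond the scatter), so this position does not penalise every change from 4-fluorophenyl. No measurement available here accounts for the difference between these steps.

Since the step from compound 1 to compound 4 changes both the substituent and its place on the aromatic ring, the compounds shown cannot assign its small size to either change alone. Also open is how the number would respond on this carbonyl carbon to a plain phenyl group, or to a hydroxyl or acetamide group in place of the amine, which would test whether tolerance extends beyond the single amine shown here.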